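Swapping a methoxy for a hydroxy on the side chain

The source may report more compounds than this note shows. Statements on the series, on what has been measured and on what is new or still open speak of the compounds shown alone.

Measured in a functional assay on HeLa cells (Homo sapiens) for cytotoxicity, read by MTT assay; on this read-out higher numbers stand for weaker inhibition and lower numbers for stronger inhibition:
Compound 1 `COC(C)CO[C@H](CC=C(C)C)C1=CC(=O)c2c(O)ccc(O)c2C1=O`: 53400 nM
Compound 2 `CCCC(CC(=O)O[C@H](CC=C(C)C)C1=CC(=O)c2c(O)ccc(O)c2C1=O)OC(C)=O`: 51200 nM

Compound 1 holds the higher of these two numbers, but its gap to compound 2 lies within the usual scatter, so neither compound ranks ahead. Compound 3 `CC(C)=CC[C@@H](OCC(C)O)C1=CC(=O)c2c(O)ccc(O)c2C1=O` is unmeasured. It keeps the core of compound 1 and has hydrogen in place of methyl on an oxygen on a saturated carbon, which reads as 2-methoxypropyl to 2-hydroxypropyl. Within the data shown here, no measured pair shows this change. Among the measured compounds shown here, the only guide is that compound 2 (51200 nM) carries a different group yet sits level with compound 1 (53400 nM). No shift beyond the scatter is therefore expected in this assay, in either direction, and the estimated step is small (a 1.2-fold lower number from compound 1 to compound 3 (0.07 log units; within the scatter)). For compound 3 the estimated value is 45000 nM within an expected range (20000 nM to 100000 nM).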

Compound 3, half-maximal inhibitory concentration: 24700 nM
Beside the measured number, compound 3's estimate is 1.8-fold (0.26 log units) above it; the range from low to high includes it.
By their numbers in this assay, from the lowest: compound 3; then compounds 2 and 1 (each within the scatter of the next).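

In this assay, the change from 2-methoxypropyl to 2-hydroxypropyl gives a 2.2-fold lower number from compound 1 to compound 3 (0.33 log units; beyond the scatter), a modest step but one beyond the scatter. Compounds 1 and 2 differ in more than one place and sit level, so they could not show that this side chain responds to any single change; this pair shows that replacing methyl with hydrogen on this oxygen alone moves the number. Nothing available accounts for the shift.

As far as these compounds go, the step rests on this one pair, so it remains open whether the same change would have a similar effect on other side chains. From the compounds shown here alone, it is also open how the number would move with an amine in place of the hydroxy, or with a longer chain such as 2-ethoxypropyl.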